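This account rests on a few compounds, and the source may have more. Where it says the series, first, only, none or still open, it means among the compounds named here.

For the measured compounds named here, in an assay on a cell-free system (plasma) for inhibition of Arachidonate 12-lipoxygenase (Rattus norvegicus) (a higher number here means a weaker inhibitor, a lower number a stronger inhibitor), compound 1 `CCOC(=O)/C(C#N)=C/c1ccc(O)c(O)c1` gives 33 nM, and compound 2 `N#C/C(=C\c1ccc(O)c(O)c1)C(=O)OCCCCc1ccccc1` gives 470 nM, the higher of the two numbers; the one measured step is a 14-fold higher number from compound 1 to compound 2 (1.15 log units; beyond the scatter). Compound 3 `N#C/C(=C\c1ccc(O)c(O)c1)C(=O)OCCCc1cccnc1` carries pyridin-3-yl in place of benzyl on a saturated chain carbon, three bonds along the chain from an oxygen next to a carbonyl group. Going by the values given here, no measured step covers an exchange of one aromatic ring for another out on this chain; the step from compound 1 to compound 2 concerns adding the chain end itself and bears only loosely on it. A step within the scatter is therefore expected, a 1.2-fold lower number from compound 2 to compound 3 (0.07 log units; within the scatter). For compound 3 the estimate is 400 nM, with a range from 150 nM to 1200 nM.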

Compound 3, half-maximal inhibitory concentration: 470 nM
The estimate for compound 3 lay 1.2-fold (0.07 log units) below the measured number, within the range that was stated.
By their numbers in this assay, from the lowest: compound 1; then compounds 2 and 3 (each within the scatter of the next).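

In this assay, pyridin-3-yl in place of benzyl, three bonds along the chain from an oxygen next to a carbonyl group, gives no change at the digits printed from compound 2 to compound 3 (within the scatter), so a ring with 1 hetero atom and 1 hydrogen-bond acceptor reads the same as the carbon-only ring here. (Pyridin-3-yl)methyl in place of hydrogen gives a 14-fold higher number from compound 1 to compound 3 (1.15 log units; beyond the scatter), so the higher number seen with phenethyl is not limited to a carbon-only ring at the chain end. No measurement here accounts for either step. As far as these compounds go, whether an amine or a carboxylic acid at the chain end, or a longer chain, would shift the number remains open.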